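Oxazole-linked indoles: a pyridyl swap for methyl

The source may hold more compounds than are shown below. What is called first, only, known or untested is meant among the compounds shown, and "the series" means these compounds.

Compound 1 `Cc1nc(-c2c[nH]c3ccccc23)co1`: 316000 nM
Compound 2 `COc1ccc(-c2nc(-c3c[nH]c4ccccc34)co2)cc1OC`: 278000 nM
Compound 3 `C(=C/c1nc(-c2c[nH]c3ccccc23)co1)\c1ccccc1`: 183000 nM

In a functional assay on LNCaP cells (Homo sapiens) for cytotoxicity, read by MTT assay, with a stated time of 48 h (on this read-out higher numbers stand for weaker inhibition and lower numbers for stronger inhibition), compound 1 gives the highest of the three numbers, yet its gap to compound 2 and to compound 3 lies within the scatter, so no order among them can be claimed. Compound 4 `c1ccc2c(-c3coc(-c4ccncc4)n3)c[nH]c2c1` differs from compound 1 by pyridin-4-yl in place of methyl on an aromatic carbon. Among the compounds with values here, replacing methyl with an aromatic group, as in compound 2 and compound 3, has not moved the numbers beyond the scatter, and no measured pair shows a larger effect for any such change. The expected step of a 1.4-fold lower number from compound 1 to compound 4 (0.14 log units; within the scatter) is therefore small, within the scatter. Compound 4 is estimated at 230000 nM, with a range from 120000 nM to 420000 nM.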

Compound 4, half-maximal inhibitory concentration: 238000 nM
For compound 4 the middle estimate is 1.0-fold (0.01 log units) below the measured one; low and high end bracket the measured number.
By their numbers in this assay, from the lowest: compounds 3, 4, 2 and 1 (each within the scatter of the next).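

Within the data shown here, this is the first pair that differs in one place only. In this assay, pyridin-4-yl in place of methyl on this aromatic carbon gives a 1.3-fold lower number from compound 1 to compound 4 (0.12 log units; within the scatter) and so leaves the number unchanged within the scatter, even though the entering group brings a six-membered aromatic ring and a ring nitrogen. Going by these compounds, whether an amine or a carboxylic acid on this same carbon would move the number beyond the scatter stays open, as does the effect of pyridin-2-yl or pyridin-3-yl there. Nothing available gives a reason for this result.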